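This account rests on a few compounds, and the source may have more. Where it says the series, first, only, none or still open, it means among the compounds named here.

Of the compounds shown here, two of a shared core have been measured in a functional assay on HeLa cells (Homo sapiens) for cytotoxicity, read by WST assay, with a stated time of 48 h; a higher number here means a weaker inhibitor, a lower number a stronger inhibitor. Compound 1 `O[C@@H](c1ccccc1)[C@H]1CO[C@H](c2ccccc2)[C@@H](C/C=C/c2ccccn2)C1` gives 33800 nM in this assay, and compound 2 `COc1ccc([C@H]2OC[C@H]([C@@H](O)c3ccc(OC)c(OC)c3)C[C@@H]2C/C=C/c2ccc(OC)c(OC)c2)cc1` gives 46700 nM in this assay; the two numbers lie within the usual scatter of each other, so neither can be called the stronger or weaker of the pair. Compound 3 `O[C@@H](c1ccccc1)[C@H]1CO[C@H](c2ccccc2)[C@@H](C/C=C/c2ccncc2)C1` has not yet been measured in this assay. It differs from compound 1 in one place: pyridin-4-yl in place of pyridin-2-yl on a double-bonded chain carbon bound to a double-bonded chain carbon. Within the data shown here, no measured pair shows this change, so its effect can only be expected. For compound 3 the step from compound 1 is estimated to be a 1.0-fold higher number from compound 1 to compound 3 (0.02 log units; within the scatter) in this assay, that is, no movement beyond the scatter in either direction. Compound 3 is therefore expected to give about 35000 nM in this assay, with a range from 12000 nM to 100000 nM.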

Compound 3, half-maximal inhibitory concentration: > 100000 nM
Compound 3: no number, only a limit; the forecaster's own chance of this, stated with the estimate: 15%; middle value at least 2.8-fold (0.45 log units) away from the limit.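

Among these compounds, until now no measured pair differed in one place, so nothing showed whether this position on the chain responds to a change at all. In this assay compound 3 gives > 100000 nM, which is a limit of the assay and not a number. Pyridin-4-yl in place of pyridin-2-yl on a double-bonded chain carbon bound to a double-bonded chain carbon gives an at least 2.9-fold higher number from compound 1 to compound 3 (0.47 log units; beyond the scatter), even though the two groups have the same atoms and the same counts, so this place distinguishes between the two pyridine isomers, and the full size of the step stays unknown: the limit of > 100000 nM in this assay, at which 1 of the 3 values shown sits.

On these data alone, whether pyridin-3-yl or a plain phenyl at this place would stand with compound 1 or with compound 3 remains open. Whether the same change would act alike on a core carrying other aryl groups also cannot be told from this single pair.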